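The source may hold more compounds than are shown below. What is called first, only, known or untested is meant among the compounds shown, and "the series" means these compounds.

Compound 1 `CCC[C@H]1OC(=O)/C=C\C=C\[C@H](O)[C@@H](O)[C@@H]1[C@H](C)COC(=O)c1ccc(O)cc1` gives 20000 nM as a measured number.
Compound 2 `CCC/C=C/[C@@H]1OC(=O)c2cc(O)cc(O)c2[C@@H]1O` gives > 50000 nM as a limit of the assay, not a number.
Compound 3 `CCC[C@@H]1C[C@H](O)[C@@H](OC)/C=C/C=C\C(=O)O1` gives 34000 nM as a measured number.

All three values come from a functional assay on MIA PaCa-2 cells (Homo sapiens) for cytotoxicity, read by MTT assay, with a stated time of 48 h (on this read-out lower numbers stand for stronger inhibition and higher numbers for weaker inhibition), and no two of these compounds differ in only one place. For the measured compounds named here, compound 3 at 34000 nM and compound 1 at 20000 nM stand within the scatter of each other, and these are the only two true numbers so far.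

Going by the values given here, compound 4 `CCC[C@@H]1C[C@H](O)[C@@H](O)/C=C/C=C\C(=O)O1` differs from compound 3 through hydrogen in place of methyl on an oxygen on a saturated carbon as its single change, methoxy to hydroxy: hydrogen in place of methyl on an oxygen on a saturated carbon. Among the compounds with values here, no measured pair shows this change, so its size in this assay has no direct precedent here. The starting point is compound 3 at 34000 nM and the expectation is no shift beyond the scatter, with no firm direction. The expected step is a 1.1-fold lower number from compound 3 to compound 4 (0.05 log units; within the scatter) as an estimate, and it stays small. The assay may also report only a limit for compound 4. Compound 4 is estimated at 30000 nM with an expected range from 12000 nM to 60000 nM for repeated measurements.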

Compound 4, half-maximal inhibitory concentration: 32000 nM
Compound 4: middle estimate off by 1.1-fold (0.03 log units), on the low side; low and high end bracket the measured number.
By their numbers in this assay, from the lowest: compounds 1, 4 and 3 (each within the scatter of the next). At a limit, above all of these: compound 2.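

In this assay, methoxy to hydroxy gives the series its first direct reading of this change: a 1.1-fold lower number from compound 3 to compound 4 (0.03 log units; within the scatter). On this core, and at numbers of this size, the methyl on this oxygen can be exchanged for hydrogen with no shift that the read-out can resolve, though this statement rests on a single pair. Both ends of the step are true numbers, so the limit of the assay does not cut it off: the limit of > 50000 nM in this assay, at which 1 of the 4 values shown sits.

The compounds shown hold only hydrogen and methyl on this oxygen, so they say nothing of how an ethyl or a longer chain, an acetyl ester, or an amine in place of the oxygen would read. Going by these compounds, one pair gives no pattern, and whether the same change would read alike on the core of compound 1 or of compound 2 stays open.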